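The source may hold more compounds than are shown below. What is called first, only, known or untested is meant among the compounds shown, and "the series" means these compounds.

Compound 1 `CCCCCCCC/C=C\CCCCCCCC[Se]CCC(=O)NCc1ccc(O)c(OC)c1` is the parent of this set. In an assay on HEK293 cells for antagonist activity at transient receptor potential cation channel subfamily V member 2 (Rattus norvegicus), read by fluorescence and calcium flux, with a stated time of 5 min (on this read-out lower numbers stand for stronger inhibition and higher numbers for weaker inhibition), compound 1 gives 1800 nM, the highest of the two numbers recorded, with compound 3 `CCCCCCCC/C=C\CCCCCCCC[Se]C[C@H](N)C(=O)NCc1ccc(O)c(OC)c1` closest at 1700 nM; the step of a 1.1-fold lower number from compound 1 to compound 3 (0.02 log units; within the scatter) is within the scatter, so the two read alike. Compound 2 `CCCCCCCCCCCCCCCC(=O)NCc1ccc(O)c(OC)c1` returns only a limit in this assay, > 10000 nM, and is set aside here, noted under (the limit of > 10000 nM in this assay, at which 1 of the 3 values shown sits).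

Compound 4 `CCCCCC[C@@H](O)C/C=C\CCCCCCCC[Se]CCC(=O)NCc1ccc(O)c(OC)c1` is compared with compound 1. The change is hydroxy in place of hydrogen on a saturated chain carbon bound to two saturated chain carbons. Among the compounds with values here, no measured step covers this exact change: the one step recorded, a 1.1-fold lower number from compound 1 to compound 3 (0.02 log units; within the scatter), puts an amino rather than a hydroxy on the chain and at a different place, and it stayed within the scatter. Taken as the nearest guide, it gives no grounds to expect a shift in this assay beyond the scatter in either direction. Compound 4 is therefore expected near its parent, with the step of no change at the digits printed from compound 1 to compound 4 (within the scatter) estimated as flat. Compound 4 is estimated at 1800 nM, between 700 nM and 5000 nM.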

Compound 4, half-maximal inhibitory concentration: > 10000 nM
Compound 4 ended at the assay's limit (the forecaster's own chance of this, stated with the estimate: 20%); at least 5.5-fold (0.74 log units) between middle value and limit.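

Hydroxy in place of hydrogen on a saturated chain carbon bound to two saturated chain carbons gives an at least 5.5-fold higher number from compound 1 to compound 4 (0.74 log units; beyond the scatter), so this position does not accept the change without effect in this assay. Within the data shown here, the one earlier step, amino in place of hydrogen on a saturated chain carbon bound to a carbonyl carbon and a saturated chain carbon, gave a 1.1-fold lower number from compound 1 to compound 3 (0.02 log units; within the scatter), so a single added group on the chain does not read alike at every place. Compound 4 returns a limit, not a number, in this assay: the limit of > 10000 nM in this assay, at which 2 of the 4 values shown sit.

From the compounds shown here alone, whether the step follows from the hydroxy itself or from its place on the chain stays open. A methoxy, an amine or a ketone on this same carbon, or a hydroxy on the opposite stereocentre, would separate these readings.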